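Working notes: compound 1 to compound 4 in cell cytotoxicity

A few compounds are considered here, and "the series" means these few. Any claim that something is new, unique, unknown or untested is made for them only; others in the source may bear on it.

Three compounds sharing the core of compound 1 `CC(C)COc1ccc2c(Cl)ccnc2c1` have numbers in a functional assay on HepG2 cells (Homo sapiens) for cytotoxicity, read by MTT assay, with a stated time of 48 h; on this read-out lower numbers stand for stronger inhibition and higher numbers for weaker inhibition. Compound 1 gives 2250 nM in this assay. Compound 2 `CN(C)CCCNc1ccnc2cc(OCc3ccc(F)cc3)ccc12` gives 1570 nM in this assay, and compound 3 `CCCCCCOc1ccc2c(NCCN(C)C)ccnc2c1` gives 1370 nM. Compound 1 thus has the highest of the three numbers, but its gaps to compound 2 and to compound 3 both fall within the scatter of repeated measurement, so nothing separates the three on these data. For the measured compounds named here, compound 2 and compound 3 carry different substituents from compound 1 at more than one place, and no single-change step between any measured pair is available.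

Compound 4 `C=CCOc1ccc2c(Cl)ccnc2c1` differs from compound 1 in one place: vinyl in place of isopropyl on a saturated chain carbon bound to an oxygen on an aromatic ring. The same difference, cut one bond further out, reads isobutyl to allyl, or isobutoxy to allyloxy. Going by the values given here, no measured pair tests a change of this kind, so there is no step in this assay to lean on. A change of this size, at this place, is expected to leave the number near that of compound 1, with no movement beyond the scatter expected. The step from compound 1 to compound 4 is estimated as a 1.1-fold higher number from compound 1 to compound 4 (0.03 log units; within the scatter). Compound 4 is expected to give about 2400 nM in this assay, with a range from 1100 nM to 5500 nM.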

Compound 4, half-maximal inhibitory concentration: 2770 nM
Beside the measured number, compound 4's estimate is 1.2-fold (0.06 log units) below it; the measured number falls inside the stated range.
By their numbers in this assay, from the lowest: compounds 3, 2, 1 and 4 (each within the scatter of the next, the first and the last beyond it).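

For the compounds shown here, this is the first single-change step: in this assay, vinyl in place of isopropyl on a saturated chain carbon bound to an oxygen on an aromatic ring gives a 1.2-fold higher number from compound 1 to compound 4 (0.09 log units; within the scatter), so the read-out does not separate isobutoxy from allyloxy at this place. Going by these compounds alone, on this one pair, losing one carbon and gaining a double bond outside aromatic rings leaves no mark beyond the scatter, which the earlier compounds, all differing from compound 1 in more than one place, could not show. Nothing available bears on why the step is this small, and the pair alone cannot say whether this place is insensitive to change in general or only to a swap between two small carbon groups.

On these data alone, whether a group of another kind in place of the allyl, such as an amine or a carboxylic acid, would move the number beyond the scatter remains open. Also open, as far as these compounds go, is whether isobutyl to allyl gives a similar step when the chlorine of compound 1 and compound 4 is replaced by a dimethylaminoalkylamine chain of the kind carried by compound 2 and compound 3.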